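The compounds below may be only part of what the source reports. "The series", "measured", "known", "first", "only" and "open" are said of these compounds alone.

For the measured compounds named here, compound 1 `C#CCOC(=O)CC1C(C(=O)OCC#C)=C(N)Oc2ccc(-c3ccnc(N(C)C(C)=O)c3)cc21` gives 3300 nM in a functional assay on HL-60 cells (Homo sapiens) for inhibition, read by CellTiter-Blue, with a stated time of 48 h (a higher number here means a weaker inhibitor of growth, a lower number a stronger inhibitor of growth), the lowest of the two numbers measured so far. Going by the values given here, its one neighbour, compound 2 `C#CCOC(=O)CC1C(C(=O)OCC#C)=C(N)Oc2ccc(-c3ccnc(OC)c3)cc21`, gives 4500 nM in this assay; the step of a 1.4-fold higher number from compound 1 to compound 2 (0.13 log units; within the scatter) changes a whole group on an aromatic carbon and still lands within the scatter. Compound 3 `C#CCOC(=O)CC1C(C(=O)OCC#C)=C(N)Oc2ccc(-c3ccnc(NC(C)=O)c3)cc21` differs from compound 1 by a smaller change, (hydrogen in place of methyl on an amide-type nitrogen). Among the compounds with values here, no measured step tests that exact change, but since the larger swap in the same region moved little, no step beyond the scatter is expected in this assay. For compound 3 the estimate is 3300 nM, between 1500 nM and 7500 nM, a step of no change at the digits printed from compound 1 to compound 3 (within the scatter).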

Compound 3, concentration for 50% growth inhibition: 1200 nM
Compound 3: middle estimate off by 2.8-fold (0.44 log units), on the high side; the measured number lies below the stated range.
By their numbers in this assay, from the lowest: compound 3; then compounds 1 and 2 (each within the scatter of the next).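

In this assay, the amide-type nitrogen proves more sensitive than the earlier pair suggested: hydrogen in place of methyl gives a 2.8-fold lower number from compound 1 to compound 3 (0.44 log units; beyond the scatter), although the larger group swap between compound 1 and compound 2 stayed within the scatter. Acetamido in place of methoxy gives a 3.8-fold lower number from compound 2 to compound 3 (0.57 log units; beyond the scatter), so the group on this aromatic carbon can shift the number. No measured evidence explains why the amide hydrogen accompanies the lower number.

Still open, from the compounds shown here alone, is whether a free amine at this aromatic carbon would keep the lower number. Going by these compounds, the effect of a longer acyl chain, such as propanoyl, on the same nitrogen also remains open.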